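Aryl swap on the saturated ring carbon: amino to methyl

A few compounds are considered here, and "the series" means these few. Any claim that something is new, unique, unknown or untested is made for them only; others in the source may bear on it.

Compound 3 `COC(=O)C1=C(C)N=C(C)/C(=C(\O)OC)C1c1cccc(N)c1` is the reference point. In a functional assay (muscle tissue) with Cavia porcellus as the target (on this read-out higher numbers stand for an effect only at larger amounts of compound and lower numbers for an effect already at smaller amounts), compound 3 gives 2000 nM, the lowest of the three numbers measured; the nearest is compound 2 `COC(=O)C1=C(C)N=C(C)/C(=C(\O)OC)C1c1ccc(I)cc1`, which in this assay gives 22900 nM, and the furthest is compound 1 `COC(=O)C1=C(C)N=C(C)/C(=C(\O)OC)C1c1cccc([N+](C)(C)C)c1`, which in this assay gives 50100 nM. Both known steps converge on compound 3: a 25-fold lower number from compound 1 to compound 3 (1.40 log units; beyond the scatter) and an 11-fold lower number from compound 2 to compound 3 (1.06 log units; beyond the scatter), each beyond the scatter and each a change of the aryl group on the same saturated ring carbon.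

Compound 4 `COC(=O)C1=C(C)N=C(C)/C(=C(\O)OC)C1c1ccccc1C` is not yet measured. Its difference from compound 3 is 2-methylphenyl in place of 3-aminophenyl on a saturated ring carbon. The step from compound 2 to compound 3 is the one that bears most directly: an aryl group without the amino gave a much higher number in this assay than the 3-aminophenyl. The exchange to 2-methylphenyl again removes the amino, so a higher number is expected for compound 4, likely smaller than the step from compound 2 but beyond the scatter. Compound 4 is therefore estimated at 10000 nM in this assay, within 2500 nM to 40000 nM; the expected step is a 5.0-fold higher number from compound 3 to compound 4 (0.70 log units; beyond the scatter).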

Compound 4, half-maximal effective concentration: 6.03 nM
Estimate against measurement, compound 4: 1700-fold (3.22 log units) above; measured number outside the range, below it.
By their numbers in this assay, from the lowest: compound 4; then compound 3; then compound 2; then compound 1.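

In this assay, the aryl group on the saturated ring carbon controls the number over a far wider span than the first three compounds showed, with a 330-fold lower number from compound 3 to compound 4 (2.52 log units; beyond the scatter) and a 3800-fold lower number from compound 2 to compound 4 (3.58 log units; beyond the scatter). The amino group of 3-aminophenyl is therefore not needed for a low number: 2-methylphenyl, with no hydrogen-bond donor or acceptor, goes well beyond it, so the earlier lead of compound 3 over compound 1 and compound 2 marks only a small part of this range. The exchange alters both the group and its place on the aryl ring, so plain phenyl, 3-methylphenyl and 2-chlorophenyl would be needed to separate the two. The data at hand offer nothing that accounts for the size of these steps.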